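The compounds below may be only part of what the source reports. "The series", "measured", "known", "first", "only" and "open" are said of these compounds alone.

In a functional assay on HeLa cells (Homo sapiens) for antiproliferative activity, read by MTT assay, with a stated time of 48 h (a lower number here means a stronger inhibitor, a higher number a weaker inhibitor), two compounds have been measured so far. Compound 1 `COc1ccc2c(/C=C/C(=O)c3cc(N)c(OC)c(OC)c3)cn(C)c2c1` gives 356 nM, and compound 2 `COc1cc(C(=O)/C=C/c2cn(C)c3ccccc23)cc(SC)c1OC` gives 105 nM. Compound 2 therefore has the lower of the two numbers, and its gap to compound 1 lies beyond the scatter.

Compound 3 `COc1cc(C(=O)/C=C/c2cn(C)c3ccccc23)cc(N)c1OC` has not yet been measured. It differs from compound 2 in one place: amino in place of methylsulfanyl on an aromatic carbon. This puts amino in place of methylsulfanyl on an aromatic carbon, ortho to a methoxy group, meta to a large group and meta to a methoxy group.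

For the measured compounds named here, no measured pair isolates this change, so the expectation rests on thin evidence. Going by the values given here, the one measured compound with an amino group is compound 1 at 356 nM, but it differs from compound 2 in more than one place and offers only a loose guide. A moderate move toward a higher number in this assay is therefore expected, and it may not clear the scatter. The expected change is a 2.1-fold higher number from compound 2 to compound 3 (0.32 log units; beyond the scatter). For compound 3 the estimated value is 220 nM, with an expected range from 70 nM to 700 nM.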

Compound 3, half-maximal inhibitory concentration: 668 nM
Estimate against measurement, compound 3: 3.0-fold (0.48 log units) below, within the range that was stated.
By their numbers in this assay, from the lowest: compound 2; then compounds 1 and 3 (each within the scatter of the next).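

In this assay, the exchange of methylsulfanyl for amino on this aromatic carbon, ortho to a methoxy group, now stands isolated, and it reads as a 6.4-fold higher number from compound 2 to compound 3 (0.80 log units; beyond the scatter). This step lies beyond the scatter, so the two groups are not interchangeable at this position on the shared core. With the amino group held in place, hydrogen in place of methoxy on an aromatic carbon gives a 1.9-fold higher number from compound 1 to compound 3 (0.27 log units; within the scatter), so of the two single changes shown, only the one from methylsulfanyl to amino separates two compounds in this assay.

The compounds shown leave open how a hydroxyl group, a dimethylamino group, an acetamide or a longer chain such as ethylsulfanyl would read at this position, and whether methylsulfanyl would keep its lower number on the core of compound 1. No measurement at hand gives any reason for the size of the step from methylsulfanyl to amino.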